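The source may hold more compounds than are shown below. What is called first, only, known or untested is meant among the compounds shown, and "the series" means these compounds.

Compound 1 `COc1cc(CNC(=O)c2cc3nc(C)c([C@H](OC(C)(C)C)C(=O)O)c(-c4cc(F)c5c(c4C)CCCO5)n3n2)ccc1F`: in an ADME assay on MT2 cells (Homo sapiens) for cytotoxicity (a lower number here means that less compound is tolerated, a higher number that more compound is tolerated), compound 1 gives > 20000 nM, which is a limit of the assay and not a number.
Compound 2 `COc1cc(F)ccc1CNC(=O)c1cc2nc(C)c([C@H](OC(C)(C)C)C(=O)O)c(-c3cc(F)c4c(c3C)CCCO4)n2n1`: in this assay compound 2 gives > 40000 nM, again only a limit.
Compound 3 `Cc1nc2cc(C(=O)NCc3ccc(F)cc3N3CCCC3=O)nn2c(-c2cc(F)c3c(c2C)CCCO3)c1[C@H](OC(C)(C)C)C(=O)O`: in this assay compound 3 gives > 40000 nM, also only a limit.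

Compound 2 therefore stands at a limit, and so do the two other values: one sits at the limit of > 20000 nM in this assay, at which 1 of the 3 values shown sits, two sit at the limit of > 40000 nM in this assay, at which 2 of the 3 values shown sit. Within the data shown here, no compound here has a real number, so none can be ranked against another.

The change to compound 4 `Cc1nc2cc(C(=O)NCCC(C)C)nn2c(-c2cc(F)c3c(c2C)CCCO3)c1[C@H](OC(C)(C)C)C(=O)O` is isobutyl in place of 4-fluoro-2-methoxyphenyl on a saturated chain carbon bound to an amide-type nitrogen. Among the measured compounds shown here, two measured steps touch the same amide-bearing position: a step that the two limits leave unreadable from compound 1 to compound 2 and a step that the two limits leave unreadable from compound 2 to compound 3. Both are unreadable. Each compares two limits, so they give no direction and no size. Nothing measured suggests that changing this position moves tolerance in this assay.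

Compound 4 is accordingly expected to remain at or near the limit, with an estimate of 40000 nM, ranging from 20000 nM to 80000 nM. The expected step is a number no higher from compound 2 to compound 4 (the limit leaves the size open), that is, no change beyond the scatter.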

Compound 4, half-maximal cytotoxic concentration: > 40000 nM
Compound 4: a limit, no number (the forecaster's own chance of this, stated with the estimate: 85%); the middle value sits exactly at the limit.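

Compound 4 stands at a limit in this assay, as do compound 1 and compound 2, so neither step to compound 4 can be read. The compounds shown leave open how much of each is actually tolerated, and whether changing this amide-bearing group shifts that tolerance at all.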